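A New Chain End in a Series Known Only by Limits

The compounds below may be only part of what the source reports. "The series", "measured", "known", "first", "only" and "open" are said of these compounds alone.

In a functional assay on Raji cells (Homo sapiens) for cytotoxicity, with a stated time of 72 h (on this read-out higher numbers stand for an effect only at larger amounts of compound and lower numbers for an effect already at smaller amounts), compound 1 `C=C[C@@](C)(/C=C/c1ccc(O)cc1)CCC1OC1(C)C` gives > 22500 nM, which is a limit. Compound 2 `C=C[C@@](C)(/C=C/c1ccc(O)cc1)CC/C=C/C(=O)OCC` gives > 26000 nM, also a limit. Compound 3 `C=C[C@@](C)(/C=C/c1ccc(O)cc1)CC/C=C/C(=O)OCc1ccccc1` gives > 26000 nM, again a limit. Compound 2 therefore has no exact number, and neither do the other two.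

Compound 4 `C=C[C@@](C)(/C=C/c1ccc(O)cc1)CC/C=C(\C)CO` differs from compound 2 by one change: 2-(hydroxymethyl)prop-1-en-1-yl in place of 2-(ethoxycarbonyl)ethenyl on a saturated chain carbon, three bonds along the chain from two double-bonded chain carbons. The measured changes offer a step that the two limits leave unreadable from compound 1 to compound 2, which touches the same place, and a step that the two limits leave unreadable from compound 2 to compound 3. Neither has a readable size, so no shift beyond the scatter is expected in this assay. The estimated change is a number no higher from compound 2 to compound 4 (the limit leaves the size open). For compound 4 the expected value is 26000 nM, with an estimated range of 10000 nM to 60000 nM.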

Compound 4, half-maximal effective concentration: > 26000 nM
Compound 4 was reported as a limit (the forecaster's own chance of this, stated with the estimate: 75%); the middle value lies on the limit itself.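

The steps from compound 1 to compound 4 and from compound 2 to compound 4 each join two limits, so neither can be read. The compounds shown leave open whether any of these chain ends changes the result in this assay.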